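The source may report more compounds than this note shows. Statements on the series, on what has been measured and on what is new or still open speak of the compounds shown alone.

Compound 2 `ClCc1cccc(Cn2cnc3c(Cl)nc(Cl)nc32)c1` stands at the low end of three compounds measured in a functional assay on SN12C cells (Homo sapiens) for cytotoxicity, read by sulforhodamine B assay, with a stated time of 48 h; a higher number here means a weaker inhibitor of growth, a lower number a stronger inhibitor of growth; compound 2 gives 2130 nM. Compound 3 `ClCc1ccc(Cn2cnc3c(Cl)nc(Cl)nc32)cc1` has the same atoms joined differently, and in this assay compound 3 gives 7240 nM; the difference between the two cores is not broken down here. Compound 1 `Nc1nc(Cl)c2ncn(Cc3ccc(CCl)cc3)c2n1` arises from compound 3 by amino in place of chloro on an aromatic carbon, and in this assay compound 1 gives 12300 nM, a step of a 1.7-fold higher number from compound 3 to compound 1 (0.23 log units; within the scatter). Compound 4 `Nc1nc(Cl)c2ncn(Cc3cccc(CCl)c3)c2n1` arises from compound 2 by amino in place of chloro on an aromatic carbon, the same change. Since the change from compound 3 to compound 1 gave a 1.7-fold higher number from compound 3 to compound 1 (0.23 log units; within the scatter), compound 4 is expected to show a similar step of a 1.7-fold higher number from compound 2 to compound 4 (0.23 log units; within the scatter). Compound 4 is therefore estimated at 3600 nM in this assay, with a plausible range of 1500 nM to 9000 nM.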

Compound 4, concentration for 50% growth inhibition: 4460 nM
Compound 4: middle estimate off by 1.2-fold (0.09 log units), on the low side, within the range that was stated.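

In this assay, amino in place of chloro on an aromatic carbon gave a 2.1-fold higher number from compound 2 to compound 4 (0.32 log units; beyond the scatter), and this step can be set beside the earlier one: the same change on two cores in this assay, a 1.7-fold higher number (0.23 log units; within the scatter) from compound 3 to compound 1 and a 2.1-fold higher number (0.32 log units; beyond the scatter) from compound 2 to compound 4, 1.2-fold (0.09 log units) apart, within the scatter of two such steps. Among the compounds shown here, the change therefore carried from one core to the other with no difference in size beyond the scatter, although only the step ending at compound 4 lies beyond the scatter by itself. Two cores are a small sample, so this does not show that the change would behave alike on any further core in this series, nor does it explain the size of the step.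

The compounds shown leave open how a methylamino or methoxy group on that same aromatic carbon would compare with amino and chloro on either core. They also leave open whether a dimethylamino group there would give a step of similar size.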